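The compounds below may be only part of what the source reports. "The series", "measured", "known", "first", "only" and "open" are said of these compounds alone.

Compound 3 `CCCOc1ccc(C(=O)Nc2cccc(Nc3ccccc3)n2)cc1` sits at the ceiling of the numbers shown so far: in an in vitro assay on HEK-tsA201 cells for antagonist activity at Neuronal acetylcholine receptor; alpha4/beta2 (Homo sapiens), read by fluorescence and calcium flux (a higher number here means a weaker inhibitor, a lower number a stronger inhibitor), compound 3 gives only a limit, > 100000 nM. Compound 1 `CCCCNc1cccc(NC(=O)c2ccc(OCCC)cc2)n1` gives 54100 nM in this assay. Compound 2 `CCCCCCNc1cccc(NC(=O)c2ccc(OCCC)cc2)n1` likewise gives only a limit in this assay, namely > 100000 nM. That is the limit of > 100000 nM in this assay, at which 2 of the 3 values shown sit. Compound 4 `CCCOc1ccc(C(=O)Nc2cccc(Nc3ccc(OC)cc3)n2)cc1` differs from compound 3 by methoxy in place of hydrogen on an aromatic carbon. Among the measured compounds shown here, no measured step touches such a carbon; each changes the group on the nitrogen on an aromatic ring: an at least 1.8-fold higher number from compound 1 to compound 2 (0.26 log units; that floor lies within the scatter), an at least 1.8-fold higher number from compound 1 to compound 3 (0.26 log units; that floor lies within the scatter) and a step that the two limits leave unreadable from compound 2 to compound 3. With nothing to move it off the limit, compound 4 is expected to stay where compound 3 stands. The step of a number no higher from compound 3 to compound 4 (the limit leaves the size open) is expected to fall within the scatter. Compound 4 is estimated at 100000 nM, with a range from 30000 nM to 300000 nM.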

Compound 4, half-maximal inhibitory concentration: > 100000 nM
Compound 4: no number, only a limit; the forecaster's own chance of this, stated with the estimate: 70%; the middle value lies on the limit itself.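

In this assay compound 4 gives only a limit, > 100000 nM, so methoxy on this aromatic carbon does not bring the anilino compound off the limit. On these data alone, its steps from compound 2 and compound 3 cannot be read, as both ends are limits, so the size of any methoxy effect stays unknown. The one readable step is an at least 1.8-fold higher number from compound 1 to compound 4 (0.26 log units; that floor lies within the scatter), and the limit now holds most of the series: the limit of > 100000 nM in this assay, at which 3 of the 4 values shown sit.

Open, as far as these compounds go, is whether an amine or a carboxylic acid at this carbon, or a propyl chain on the nitrogen, would give a number under the limit.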